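The compounds below may be only part of what the source reports. "The series", "measured", "known", "first", "only" and "open" are said of these compounds alone.

Three compounds have been measured so far in a functional assay on NCI-H23 cells (Homo sapiens) for antiproliferative activity, read by sulforhodamine B assay (a higher number here means a weaker inhibitor of growth, a lower number a stronger inhibitor of growth), as follows:

- Compound 1 `CC(C)(C)CCOc1cccc(O)c1C(=O)/C=C/c1ccc(C(=O)O)cc1` gives 4770 nM
- Compound 2 `CCCCCCOc1cccc(O)c1C(=O)/C=C/c1ccc(O)cc1` gives > 30000 nM
- Compound 3 `O=C(/C=C/c1ccc(O)cc1)c1c(O)cccc1OCCC1CCCCC1` gives > 30000 nM

Compound 1 is the only one of the three with a number, 4770 nM, as its read-out. Compound 2 gives > 30000 nM as a limit of the assay and not a number. Compound 3 gives > 30000 nM as a limit too, and the limit of > 30000 nM in this assay, at which 2 of the 3 values shown sit, is where it stands in this series.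

Compound 4 `CCCCOc1cccc(O)c1C(=O)/C=C/c1ccc(O)cc1` has not yet been measured. The change from compound 3 is ethyl in place of cyclohexyl on a saturated chain carbon, two bonds along the chain from an oxygen on an aromatic ring, which turns 2-cyclohexylethoxy into butoxy.

Within the data shown here, only one measured step bears on this change, and it is a step that the two limits leave unreadable from compound 2 to compound 3 at that same chain carbon. With compound 3 at the limit of > 30000 nM in this assay, at which 2 of the 3 values shown sit, as its starting point, that step offers no size to carry over, so no clear move in either direction is expected in this assay and compound 4 is expected to stay at or near the limit. The step expected is a number no higher from compound 3 to compound 4 (the limit leaves the size open) and it remains a rough estimate. For compound 4 the estimated value is 30000 nM with an expected range from 12000 nM to 60000 nM and a report of only a limit as the likeliest outcome.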

Compound 4, concentration for 50% growth inhibition: > 30000 nM
Compound 4 ended at the assay's limit (the forecaster's own chance of this, stated with the estimate: 65%); the middle value sits exactly at the limit.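

Compound 4 joins compound 2 and compound 3 at a limit of the assay and not a number, so no step among these three compounds can be read: the limit of > 30000 nM in this assay, at which 3 of the 4 values shown sit. The compounds shown leave open whether the chains on these three compounds differ at all in this assay.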